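Working notes: extending the pentyloxy chain of compound 3

A few compounds are considered here, and "the series" means these few. Any claim that something is new, unique, unknown or untested is made for them only; others in the source may bear on it.

Measured in a functional assay on brain (Rattus norvegicus, strain Wistar) for inhibition; a higher number here means a weaker inhibitor, a lower number a stronger inhibitor:
- compound 1 `CCCc1ccc(-c2c(C)[nH]c(=O)n2C2CCCCC2)cc1`: 13900 nM
- compound 2 `CCCCCc1ccc(-c2c(C)[nH]c(=O)n2C2CCCCC2)cc1`: 10600 nM
- compound 3 `CCCCCOc1ccc(-c2c(C)[nH]c(=O)n2C2CCCCC2)cc1`: 9100 nM

Compound 3 cannot be separated from the other two on these numbers: a 1.5-fold lower number from compound 1 to compound 3 (0.18 log units; within the scatter) and a 1.2-fold lower number from compound 2 to compound 3 (0.07 log units; within the scatter) both lie within the scatter. Compound 4 `CCCCCCOc1ccc(-c2c(C)[nH]c(=O)n2C2CCCCC2)cc1` differs from compound 3 by one change: methyl in place of hydrogen on a saturated chain carbon, five bonds along the chain from an oxygen on an aromatic ring. Going by the values given here, the closest precedent is the chain extension a 1.3-fold lower number from compound 1 to compound 2 (0.12 log units; within the scatter), also within the scatter. Among the compounds with values here, no measured step in this small set exceeds the scatter, so no clear shift is expected in this assay here. The expected change is a 1.1-fold lower number from compound 3 to compound 4 (0.03 log units; within the scatter), which would stay within the scatter. Compound 4 is estimated at 8500 nM, with an expected range of 4000 nM to 18000 nM.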

Compound 4, half-maximal inhibitory concentration: 8500 nM
The estimate for compound 4 equals the measured number at the digits printed, within the range that was stated.
By their numbers in this assay, from the lowest: compounds 4, 3, 2 and 1 (each within the scatter of the next).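

Extending pentyloxy to hexyloxy, with methyl in place of hydrogen five bonds along the chain from the oxygen on the aromatic ring, gives no readable shift in this assay (a 1.1-fold lower number from compound 3 to compound 4 (0.03 log units; within the scatter)). The same holds for hexyloxy in place of pentyl (a 1.2-fold lower number from compound 2 to compound 4 (0.10 log units; within the scatter)) and hexyloxy in place of propyl (a 1.6-fold lower number from compound 1 to compound 4 (0.21 log units; within the scatter)), so all four compounds remain within the scatter. No supporting evidence bears on this result.

Still open, on these data alone, is whether a longer chain such as octyloxy, or an amine or a carboxylic acid carried on this chain, would move the number beyond the scatter.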